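Biaryl-piperidinol series: forecasting the dimethylaminomethyl analogue

The source may hold more compounds than are shown below. What is called first, only, known or untested is meant among the compounds shown, and "the series" means these compounds.

Measured so far:
compound 1 `Cn1nc2c(=O)n(CC3(O)CCN(Cc4ccc(-c5ccco5)cc4Cl)CC3)cnc2c1-c1ccc(C(F)(F)F)cc1` gives 530 nM
compound 2 `Cn1nc2c(=O)n(CC3(O)CCN(Cc4ccc(-c5ccncc5)cc4Cl)CC3)cnc2c1-c1ccc(CN)cc1` gives 257 nM
compound 3 `Cn1nc2c(=O)n(CC3(O)CCN(Cc4ccc(-c5ccsc5)cc4Cl)CC3)cnc2c1-c1ccc(CN)cc1` gives 59.5 nM

All three were run in an assay on isolated protein for inhibition of ubiquitin carboxyl-terminal hydrolase 7 (Homo sapiens), with stated times of 30 min and 2 h; a higher number here means a weaker inhibitor, a lower number a stronger inhibitor. Compound 1 carries the highest number of the three: compound 2 sits a little below it and compound 3 well below it. Going by the values given here, the only single-point step among the measured compounds is a 4.3-fold lower number from compound 2 to compound 3 (0.64 log units; beyond the scatter), which concerns the ring on the chlorophenyl side and does not touch the position varied here.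

Compound 4 `CN(C)Cc1ccc(-c2c3ncn(CC4(O)CCN(Cc5ccc(-c6ccco6)cc5Cl)CC4)c(=O)c3nn2C)cc1` is the next compound; it differs from compound 1 as follows: (dimethylamino)methyl in place of trifluoromethyl on an aromatic carbon. Compounds 1 and 2 differ at this same phenyl position but also in the ring on the other side, so their values can only be read together: compound 1 gives 530 nM and compound 2 gives 257 nM. Both compounds bearing an aminomethyl on that phenyl, compound 2 and compound 3, sit below compound 1, though the second change in each pair blurs how much of that is the phenyl substituent. Among the compounds with values here, no measured step isolates trifluoromethyl against (dimethylamino)methyl.

On this basis a modest move toward lower numbers is expected for compound 4 rather than a large one: a 2.4-fold lower number from compound 1 to compound 4 (0.38 log units; beyond the scatter). Compound 4 is estimated at 220 nM, with a range of 80 nM to 600 nM.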

Compound 4, half-maximal inhibitory concentration: 131 nM
Estimate against measurement, compound 4: 1.7-fold (0.23 log units) above, and the stated range covers the measured number.
By their numbers in this assay, from the lowest: compound 3; then compounds 4 and 2 (each within the scatter of the next); then compound 1.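

Going by these compounds alone, the swap of trifluoromethyl for (dimethylamino)methyl, on an aromatic carbon para to a large group, is isolated here for the first time in this assay (a 4.0-fold lower number from compound 1 to compound 4 (0.61 log units; beyond the scatter)), and the result shows that this position responds to the substituent with the rest of the molecule held constant. Leaving and entering groups each count 4 heavy atoms, so the step comes without a change in that count, while the entering group brings 1 hydrogen-bond acceptor and the leaving group has 0. No measurement at hand accounts for the step.

Open, on these data alone, is how an aminomethyl, a morpholin-4-ylmethyl or a carboxylic acid on this phenyl would compare with the (dimethylamino)methyl of compound 4 with the rest held constant, since compound 2 and compound 3 carry aminomethyl but also differ from compound 4 in the ring on the chlorophenyl side. Also open, as far as these compounds go, is whether the step from trifluoromethyl to (dimethylamino)methyl keeps its size when the ring of compound 3 stands on that side.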